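The compounds below may be only part of what the source reports. "The series", "measured", "known", "first", "only" and "open" are said of these compounds alone.

Measured in a functional assay on MGC-803 cells (Homo sapiens) for inhibition, read by MTT assay, with a stated time of 48 h; on this read-out lower numbers stand for stronger inhibition and higher numbers for weaker inhibition:
- compound 1 `CCN1CCN(C(=S)SCCCOc2ccc3c(=O)c(-c4ccc(OC)cc4)coc3c2)CC1`: 54000 nM
- compound 2 `COc1ccc(-c2coc3cc(OCCCSC(=S)N4CCN(C(C)=O)CC4)ccc3c2=O)cc1`: 39400 nM
- compound 3 `COc1ccc(-c2coc3cc(OCCCSC(=S)N4CCN(C(=O)OC(C)(C)C)CC4)ccc3c2=O)cc1`: 6070 nM

Compound 1 stands at the high end of these numbers, which means at the weaker end of the read-out. Its nearest measured neighbour is reached by a 1.4-fold lower number from compound 1 to compound 2 (0.14 log units; within the scatter), and its furthest by an 8.9-fold lower number from compound 1 to compound 3 (0.95 log units; beyond the scatter).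

Compound 4 `COc1ccc(-c2coc3cc(OCCCCBr)ccc3c2=O)cc1` has not yet been measured. It differs from compound 1 by a group of 2 heavy atoms (1 carbon, 1 bromine; no ring) in place of a group of 11 heavy atoms (7 carbon, 2 nitrogen, 2 sulfur; one six-membered non-aromatic ring with 2 hetero atoms), on a saturated chain carbon, three bonds along the chain from an oxygen on an aromatic ring. Bromomethyl enters, and the group with the six-membered non-aromatic ring leaves, on a saturated chain carbon, three bonds along the chain from an oxygen on an aromatic ring.

The measured steps bear on this change only indirectly, since each alters just the group on an amine nitrogen in a ring. The remaining step is a 6.5-fold lower number from compound 2 to compound 3 (0.81 log units; beyond the scatter). Only the two steps that introduce tert-butoxycarbonyl go beyond the scatter, and compound 4 does not carry that group. Among the compounds with values here, no measured compound shows what happens when the whole ring group is lost, so the uncertainty is wide.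

In this assay, no step beyond the scatter is expected, and the estimated step is a 1.4-fold lower number from compound 1 to compound 4 (0.13 log units; within the scatter). The estimated value for compound 4 is 40000 nM, with an expected range of 12000 nM to 130000 nM.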

Compound 4, half-maximal inhibitory concentration: 52700 nM
Compound 4: middle estimate off by 1.3-fold (0.12 log units), on the low side, within the range that was stated.
By their numbers in this assay, from the lowest: compound 3; then compounds 2, 4 and 1 (each within the scatter of the next).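

In this assay, putting bromomethyl in place of the group with the six-membered non-aromatic ring, on a saturated chain carbon, three bonds along the chain from an oxygen on an aromatic ring, gives a 1.0-fold lower number from compound 1 to compound 4 (0.01 log units; within the scatter). Losing the whole ring group, which the earlier steps could not test, therefore leaves the read-out of compound 1 within the scatter, so this ring group with ethyl on its amine nitrogen cannot be told apart from bromomethyl here, whereas the same ring group with tert-butoxycarbonyl gives an 8.9-fold lower number from compound 1 to compound 3 (0.95 log units; beyond the scatter). Nothing shown here explains why compound 1 and compound 4 read alike.

The compounds shown leave open whether other groups at the end of this chain, such as a primary amine or a carboxylic acid, would also stay within the scatter of compound 1. They also leave open whether a longer chain would change the read-out, either with bromomethyl replaced by another small group or with the tert-butoxycarbonyl ring group of compound 3 retained.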